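The source may report more compounds than this note shows. Statements on the series, on what has been measured and on what is new or still open speak of the compounds shown alone.

The measured compounds:
Compound 1 `COc1cccc(-c2csc(C3(CNC(=O)c4ccc(Cn5nc(C)cc5C)cc4)CCOCC3)n2)c1`: in a physicochemical assay for solubility, read by chemiluminescence, in phosphate buffer, measured as kinetic solubility, at pH 7.4 (a lower number here means a less soluble compound, a higher number a more soluble compound), compound 1 gives 72000 nM.
Compound 2 `O=C(NCC1(c2nc(-c3ccccc3)cs2)CCOCC1)c1ccc(Nc2nncs2)cc1`: in this assay compound 2 gives 29000 nM.
Compound 3 `COc1ccccc1-c1csc(C2(CNC(=O)c3ccc(Cn4nc(C)cc4C)cc3)CCOCC2)n1`: in this assay compound 3 gives 78000 nM.

Among these three, compound 2 stands lowest in this assay; compound 1 and compound 3 both lie beyond the scatter above it. Among the measured compounds shown here, the only step measured between two of them, a 1.1-fold higher number from compound 1 to compound 3 (0.03 log units; within the scatter), stays within the scatter and concerns a different part of the shared core.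

Compound 4 `O=C(NCC1(c2nc(-c3ccccc3)cs2)CCOCC1)c1ccc(Nc2ccccn2)cc1` differs from compound 2 by pyridin-2-yl in place of 1,3,4-thiadiazol-2-yl on a nitrogen on an aromatic ring. For the measured compounds named here, no measured pair carries this change, and the one step that is known bears on another position, so it offers no direct guidance on direction or size. The change sits in a part of compound 2 that compound 1 and compound 3 do not share, so their values cannot be read across either.

With no evidence pointing one way, compound 4 is expected to give 25000 nM in this assay, with a wide range from 8000 nM to 70000 nM. The expected step, a 1.2-fold lower number from compound 2 to compound 4 (0.06 log units; within the scatter), is estimated to fall within the scatter.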

Compound 4, solubility: 12000 nM
Beside the measured number, compound 4's estimate is 2.1-fold (0.32 log units) above it, and the stated range covers the measured number.
By their numbers in this assay, from the lowest: compound 4; then compound 2; then compounds 1 and 3 (each within the scatter of the next).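

Exchanging the (1,3,4-thiadiazol-2-yl)amino group for (pyridin-2-yl)amino does move the read-out in this assay, with a 2.4-fold lower number from compound 2 to compound 4 (0.38 log units; beyond the scatter) on this modest change at the nitrogen on an aromatic ring. Among the compounds shown here, the only earlier step, a 1.1-fold higher number from compound 1 to compound 3 (0.03 log units; within the scatter), concerned another part of the molecule and stayed within the scatter, so this is the first sign that the end of the molecule carrying this nitrogen can register a real difference. Nothing available here accounts for this step.

The compounds shown leave open whether the step follows the change from a five-membered to a six-membered aromatic ring or the change in the number of hetero atoms. Also open, as far as these compounds go, is how a pyrimidin-2-yl group at this nitrogen, or a pyridin-2-yl ring bearing an amine or a carboxylic acid, would compare.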